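Swapping a Dibromophenyl Amide for a Bromohydroxyphenyl Amide

The source may report more compounds than this note shows. Statements on the series, on what has been measured and on what is new or still open speak of the compounds shown alone.

Three amides have been tested in an assay on isolated protein for inhibition of thiosulfate sulfurtransferase (Homo sapiens), with a stated time of 60 min, in the absence of a further agent (a higher number here means a weaker inhibitor, a lower number a stronger inhibitor), so far. Compound 1 `COc1c(Br)cc(Br)cc1C(=O)Nc1ccccc1` reaches only the limit of this assay, giving > 100000 nM. Compound 2 `O=C(Nc1ccc(Sc2nc3ccccc3s2)c(Cl)c1)c1cc(Br)cc(Br)c1` likewise gives > 100000 nM, a limit rather than a number. Compound 3 `O=C(Nc1ccc(Sc2nc3ccccc3s2)cc1)c1cc(Br)cc(Br)c1` also stops at the limit, with > 100000 nM. Going by the values given here, the single change among them, a step that the two limits leave unreadable from compound 2 to compound 3, therefore cannot be sized, as the limit of > 100000 nM in this assay, at which 3 of the 3 values shown sit, shows every value sitting at the same limit.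

Compound 4 `O=C(Nc1ccc(Sc2nc3ccccc3s2)cc1)c1cccc(Br)c1O` is the next step from compound 3: 3-bromo-2-hydroxyphenyl in place of 3,5-dibromophenyl on a carbonyl carbon. Among the compounds with values here, no measured step bears on this change with a readable size, so the expectation for compound 4 rests only on the limits already seen. The estimated step of an at least 1.2-fold lower number from compound 3 to compound 4 (0.09 log units; that floor lies within the scatter) is thus uncertain, with a real chance that compound 4 again returns only a limit. Compound 4 is expected to give about 80000 nM in this assay, within a range from 5000 nM to 200000 nM.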

Compound 4, half-maximal inhibitory concentration: > 100000 nM
Compound 4: only a limit was reported; the forecaster's own chance of this, stated with the estimate: 60%; at least 1.2-fold (0.09 log units) between middle value and limit.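

Compound 3 and compound 4 both stop at a limit, so no size can be read for the step between them, nor for any other step here: the limit of > 100000 nM in this assay, at which 4 of the 4 values shown sit. The compounds shown leave open which structure, if any, gives a readable number in this assay rather than a limit.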